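Aryl swaps on the carbon double-bonded to nitrogen

A few compounds are considered here, and "the series" means these few. Any claim that something is new, unique, unknown or untested is made for them only; others in the source may bear on it.

Compound 3 `Cc1c(C(=O)N/N=C\c2ccccn2)oc2cccc(O)c12` carries pyridin-2-yl on a carbon with a double bond to nitrogen. In a functional assay on PC-3 cells (Homo sapiens) for inhibition (on this read-out higher numbers stand for weaker inhibition and lower numbers for stronger inhibition), compound 3 gives only a limit, >= 40000 nM. Compound 1 `Cc1c(C(=O)N/N=C\c2cccc(F)c2)oc2cccc(O)c12` likewise gives in this assay a limit, >= 40000 nM. Compound 2 `Cc1c(C(=O)N/N=C\c2cccnc2)oc2cccc(O)c12` also gives in this assay a limit, >= 40000 nM. All three values sit at the limit of >= 40000 nM in this assay, at which 3 of the 3 values shown sit. The step that the two limits leave unreadable from compound 1 to compound 3, the step that the two limits leave unreadable from compound 2 to compound 3 and the step that the two limits leave unreadable from compound 1 to compound 2 are accordingly of unreadable size, and no ranking among compounds 1, 2 and 3 can be drawn from them.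

Compound 4 `Cc1c(C(=O)N/N=C\c2cc(F)ccc2O)oc2cccc(O)c12` differs from compound 3 by 5-fluoro-2-hydroxyphenyl in place of pyridin-2-yl on a carbon with a double bond to nitrogen. Among the measured compounds shown here, none of the measured steps bears on this change with a readable size; every aryl swap measured so far ended at the limit. Compound 4 is therefore expected to remain close to that limit in this assay, with an estimated step of an at least 1.1-fold lower number from compound 3 to compound 4 (0.05 log units; that floor lies within the scatter) that may again not be readable. The estimate for compound 4 in this assay is 35000 nM, within 8000 nM to 60000 nM.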

Compound 4, half-maximal inhibitory concentration: 3170 nM
The estimate for compound 4 lay 11-fold (1.04 log units) above the measured number; measured number outside the range, below it.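

In this assay the aryl group on a carbon with a double bond to nitrogen can clearly change the read-out: 5-fluoro-2-hydroxyphenyl gives an at least 12-fold lower number from compound 3 to compound 4 (1.10 log units; beyond the scatter) and an at least 12-fold lower number from compound 2 to compound 4 (1.10 log units; beyond the scatter). Hydroxy in place of hydrogen on an aromatic carbon is the only difference between compound 1 and compound 4, and it gives an at least 12-fold lower number from compound 1 to compound 4 (1.10 log units; beyond the scatter), so this one group separates a fluorinated phenyl at the limit from a measurable number. All three sizes are floors rather than exact gaps, and the steps among compounds 1, 2 and 3 remain unreadable: the limit of >= 40000 nM in this assay, at which 3 of the 4 values shown sit.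

From the compounds shown here alone, whether the fluoro of compound 4 contributes once the hydroxy is present remains open. Also open, going by these compounds, is whether an amine or a carboxylic acid in place of the hydroxy would give a measurable number.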